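The source may hold more compounds than are shown below. What is called first, only, known or untested is meant among the compounds shown, and "the series" means these compounds.

Compound 1 `CCCc1nnc(O)n2c(CCC)nc(C)c12`: 16000 nM
Compound 2 `CCc1nnc(O)n2c(CC)nc(C)c12`: 24000 nM

In a functional assay for inhibition, with Homo sapiens as the target (a lower number here means a stronger inhibitor, a higher number a weaker inhibitor), compound 2 gives the higher of the two numbers, yet compound 1 lies within the usual scatter of it, so neither can be called the stronger inhibitor. Compound 3 `CCCc1nc(C)c2c(CC)nnc(O)n12` differs from compound 2 by methyl in place of hydrogen on a saturated chain carbon, two bonds along the chain from an aromatic carbon. Within the data shown here, no measured pair mirrors this step. The two measured values sit within the scatter of each other, which gives no ground for a large change. Compound 3 is therefore expected to show a step of a 1.3-fold lower number from compound 2 to compound 3 (0.10 log units; within the scatter), within the scatter. In this assay compound 3 is estimated at 19000 nM, with a range from 9000 nM to 40000 nM.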

Compound 3, half-maximal inhibitory concentration: 15600 nM
Estimate against measurement, compound 3: 1.2-fold (0.09 log units) above; the measured number falls inside the stated range.
By their numbers in this assay, from the lowest: compounds 3, 1 and 2 (each within the scatter of the next).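

In this assay, methyl in place of hydrogen on a saturated chain carbon, two bonds along the chain from an aromatic carbon, gives a 1.5-fold lower number from compound 2 to compound 3 (0.19 log units; within the scatter) and hydrogen in place of methyl at such a carbon gives a 1.0-fold lower number from compound 1 to compound 3 (0.01 log units; within the scatter) as its result. Both steps lie within the scatter, so ethyl and propyl at these places cannot be told apart in these three compounds. Nothing available explains this result. On these data alone, whether a longer chain or an amine at this place would give a step beyond the scatter remains open.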